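Chloro for Fluoro on the Shared Core of Compound 3

The compounds below may be only part of what the source reports. "The series", "measured", "known", "first", "only" and "open" are said of these compounds alone.

Compound 1 `CN1CCCN(CCn2ccc3ccc(Br)cc32)CC1`: 93%
Compound 2 `CN1CCCN(CCn2ccc3cc(Br)ccc32)CC1`: 65%
Compound 3 `CN1CCCN(CCn2ccc3ccc(F)cc32)CC1`: 60%

In an assay on HEK293 cells for binding affinity to 5-hydroxytryptamine receptor 7 (Homo sapiens), read by radioligand binding, tested at 1 uM (on this read-out higher numbers stand for more inhibition at the one concentration tested (going by the name of the read-out) and lower numbers for less inhibition), compound 3 gives 60%, the lowest of the three numbers. Compound 2 sits within the scatter of it at 65%, whereas compound 1 is well clear of it and gives 93%. Compound 4 `CN1CCCN(CCn2ccc3ccc(Cl)cc32)CC1` differs from compound 3 by chloro in place of fluoro on an aromatic carbon. For the measured compounds named here, the one measured step that bears on this change is a number 33 percentage points lower from compound 1 to compound 3 (beyond the scatter), so the halogen at this place clearly matters here. With bromo giving the high number and fluoro the low one, chloro at the same place is expected to land between them, an upward step of a number 18 percentage points higher from compound 3 to compound 4 (beyond the scatter). Compound 4 is therefore estimated at 78% in this assay, with a range from 62% to 92%.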

Compound 4, a percentage reported as inhibition, at one concentration (the size of the read-out at that concentration, not a potency): 85%
Compound 4: middle estimate off by 7 percentage points, on the low side; low and high end bracket the measured number.
By their numbers in this assay, from the lowest: compounds 3 and 2 (each within the scatter of the next); then compounds 4 and 1 (each within the scatter of the next).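

In this assay the change from fluoro to chloro at this place brings a number 25 percentage points higher from compound 3 to compound 4 (beyond the scatter) and so shows that the low number does not extend to every lighter halogen. The change from bromo to chloro gives a number 8 percentage points lower from compound 1 to compound 4 (within the scatter) and so leaves these two halogens indistinguishable here, with only fluoro standing clear of both.

Open, as far as these compounds go, is whether a non-halogen group at this place, such as methoxy or nitrile, would keep the number as high, and how chloro would read at the place bromo holds in compound 2. No measured evidence is available to account for these differences.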